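A few compounds are considered here, and "the series" means these few. Any claim that something is new, unique, unknown or untested is made for them only; others in the source may bear on it.

Compound 1 `CCN(CC)CCCCCN/C(C)=N\c1ccnc2cc(Cl)ccc12`, compound 2 `C/C(=N/c1ccnc2cc(Cl)ccc12)NCCCCN1CCCCC1` and compound 3 `CC(C)/C(=N/c1ccnc2cc(Cl)ccc12)NCCCN1CCCCC1` have each been measured in an ADME assay (liver) for metabolic stability, with Liver microsome (Homo sapiens) as the target, read by LC-MS, using microsomes, tested at 1 uM; on this read-out lower numbers stand for a shorter-lived compound and higher numbers for a longer-lived compound. Compound 1 gives 0.933 h in this assay. For compound 2 this assay reports only a limit, > 1 h. Compound 3 gives 0.483 h, the lowest of the two numbers, though its gap to compound 1 lies within the usual scatter. The difference between the cores of compound 2 and compound 3 is not broken down here.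

Compound 1 differs from compound 2 by (diethylamino)methyl in place of piperidin-1-yl on a saturated chain carbon, four bonds along the chain from an amine nitrogen. That change produced an at least 1.0-fold lower number from compound 2 to compound 1 (0.03 log units; that floor lies within the scatter). Compound 2 sits at the limit of > 1 h in this assay, at which 1 of the 3 values shown sits, which leaves the true size of that step open.

Compound 4 `CCN(CC)CCCCN/C(=N\c1ccnc2cc(Cl)ccc12)C(C)C` has not yet been measured in this assay. It differs from compound 3 by (diethylamino)methyl in place of piperidin-1-yl on a saturated chain carbon, three bonds along the chain from an amine nitrogen. The place is not the same word for word: here the change sits three bonds along the chain from an amine nitrogen, where in compound 1 it sat four bonds along, so it is the same kind of change rather than the same change. The expectation for the new compound rests on an at least 1.0-fold lower number from compound 2 to compound 1 (0.03 log units; that floor lies within the scatter), a step that did not move the half-life beyond the scatter. Compound 4 is accordingly expected to show a step of a 1.0-fold higher number from compound 3 to compound 4 (0.02 log units; within the scatter) in this assay. Compound 4 is expected to give about 0.5 h, with a likely span from 0.3 h to 0.9 h.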

Compound 4, half-life: 0.917 h
Compound 4: middle estimate off by 1.8-fold (0.26 log units), on the low side; the whole stated range lies below it.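

Carried to the core of compound 3, (diethylamino)methyl in place of piperidin-1-yl gave a 1.9-fold higher number from compound 3 to compound 4 (0.28 log units; within the scatter) in this assay, so on this core the change left the half-life within the scatter. Set beside the earlier case, the two steps cannot be told apart on this evidence: the same change on two cores in this assay, an at least 1.0-fold lower number (0.03 log units; that floor lies within the scatter) from compound 2 to compound 1 and a 1.9-fold higher number (0.28 log units; within the scatter) from compound 3 to compound 4; the limit leaves it open whether they differ The pair does not show that the change carries over from one core to another with the same size, for the two cases also sit at different places on the chain, three bonds along in one and four in the other, and two cores are too few to support a rule for the series.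

Compound 2 remains a limit, > 1 h, and not a number. The compounds shown leave open how the half-life would respond to another amine at the end of the chain, such as a dimethylamino group, or to a longer chain on the core of compound 3.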